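Swapping a Ring Carbon for Oxygen on the Amide

A few compounds are considered here, and "the series" means these few. Any claim that something is new, unique, unknown or untested is made for them only; others in the source may bear on it.

Compound 1 `COc1ccc(C(C)(C)C)cc1CN[C@H]1[C@H](C(C)(C)C)[C@@H](C(=O)O)N(C(=O)C2CCCCC2)[C@H]1c1ccccc1` is tested in an assay on HBE cells for positive allosteric modulation of Cystic fibrosis transmembrane conductance regulator variant F508del (Homo sapiens) (on this read-out higher numbers stand for an effect only at larger amounts of compound and lower numbers for an effect already at smaller amounts), where compound 1 gives 113 nM. That is the lowest of the three numbers, but the gaps to compound 3 `COc1ncc(C2CCC2)cc1CN[C@H]1[C@H](C(C)(C)C)[C@@H](C(=O)O)N(C(=O)C2CCCCC2)[C@H]1c1ccccc1`, which gives 184 nM, and to compound 2 `COc1ccc(C23CC4CC42C3)cc1CN[C@H]1[C@H](C(C)(C)C)[C@@H](C(=O)O)N(C(=O)C2CCCCC2)[C@H]1c1ccccc1`, which gives 190 nM, stay within the scatter: a 1.6-fold higher number from compound 1 to compound 3 (0.21 log units; within the scatter) and a 1.7-fold higher number from compound 1 to compound 2 (0.23 log units; within the scatter). Compound 4 `COc1ccc(C(C)(C)C)cc1CN[C@H]1[C@H](C(C)(C)C)[C@@H](C(=O)O)N(C(=O)[C@@H]2CCCCO2)[C@H]1c1ccccc1` differs from compound 1 by oxan-2-yl in place of cyclohexyl on a carbonyl carbon. Neither measured step touches this part of the shared core; both change a group on an aromatic carbon, and both were small. Nothing measured bears directly on the new change, so in this assay the expected step is a 1.3-fold higher number from compound 1 to compound 4 (0.12 log units; within the scatter), no larger than the scatter. Compound 4 is estimated at 150 nM, with a range from 60 nM to 400 nM.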

Compound 4, half-maximal effective concentration: 321 nM
For compound 4 the middle estimate is 2.1-fold (0.33 log units) below the measured one, and the stated range covers the measured number.
By their numbers in this assay, from the lowest: compounds 1, 3, 2 and 4 (each within the scatter of the next, the first and the last beyond it).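

In this assay, among these compounds, the change on the carbonyl carbon gives a 2.8-fold higher number from compound 1 to compound 4 (0.45 log units; beyond the scatter), the only step so far that goes beyond the scatter. The group keeps its ring size and heavy-atom count, so exchanging a single ring carbon for oxygen, which adds one hydrogen-bond acceptor, is enough to shift the number here, while both earlier changes on the aromatic part stayed within the scatter. No available evidence explains this shift.

On these data alone, it remains open whether the shift depends on where the hetero atom sits or which atom it is, as oxan-4-yl or piperidin-2-yl would show. As far as these compounds go, the opposite stereocentre of oxan-2-yl also remains open.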